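A few compounds are considered here, and "the series" means these few. Any claim that something is new, unique, unknown or untested is made for them only; others in the source may bear on it.

Measured so far:
- compound 1 `O=S(=O)(Nc1nccs1)c1ccc2c(c1)OCC[C@@H]2c1ccc(C(F)(F)F)cc1-c1ccc(F)cc1` gives 39000 nM in a physicochemical assay for solubility; on this read-out lower numbers stand for lower solubility and higher numbers for higher solubility
- compound 2 `O=S(=O)(Nc1nccs1)c1ccc2c(c1)OCC[C@H]2c1ccc(C(F)(F)F)cc1-c1ccc(F)cc1` gives 147000 nM
- compound 3 `O=S(=O)(Nc1ncccn1)c1ccc2c(c1)CC[C@@H]2c1ccc(C(F)(F)F)cc1-c1ccc(F)nc1` gives 40000 nM

Compound 1 holds the lowest of these three numbers. Compound 3 sits within the scatter of it, so the two cannot be told apart. Compound 2 stands further off: a 3.8-fold higher number from compound 1 to compound 2 (0.58 log units; beyond the scatter), a step that rests on (the fact that compounds 1 and 2 differ only in the configuration as drawn), since the two compounds share every atom and bond.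

Compound 4 `Cc1nc(-c2cc(C(F)(F)F)ccc2[C@H]2CCOc3cc(S(=O)(=O)Nc4nccs4)ccc32)co1` is not yet measured. It differs from compound 1 in one place: 2-methyl-1,3-oxazol-4-yl in place of 4-fluorophenyl on an aromatic carbon. Within the data shown here, none of the measured steps bears on this change; the only step available is the swap of configuration between compound 1 and compound 2, which says nothing about trading a 4-fluorophenyl for a 2-methyl-1,3-oxazol-4-yl. With no guide from the measured compounds, the expectation is a step no larger than the scatter, if any, in this assay: a 1.8-fold higher number from compound 1 to compound 4 (0.25 log units; within the scatter) is the estimated step. Compound 4 is therefore expected to give about 70000 nM, with a range from 25000 nM to 200000 nM.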

Compound 4, solubility: 61000 nM
Beside the measured number, compound 4's estimate is 1.1-fold (0.06 log units) above it; low and high end bracket the measured number.
By their numbers in this assay, from the lowest: compounds 1, 3 and 4 (each within the scatter of the next); then compound 2.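

In this assay, putting 2-methyl-1,3-oxazol-4-yl in place of 4-fluorophenyl on this aromatic carbon, ortho to a large group and meta to a trifluoromethyl group, gives a 1.6-fold higher number from compound 1 to compound 4 (0.19 log units; within the scatter). The earlier compounds shown here showed only a change of configuration on this scaffold; this result adds that a five-membered aromatic ring with 2 hetero atoms and 2 hydrogen-bond acceptors can replace a six-membered aromatic ring of carbon only here without a step that stands out from the scatter. Nothing established for these compounds explains this step.

From the compounds shown here alone, whether an amine or a carboxylic acid on this same carbon would also stay within the scatter remains open. So does whether the same swap would give a similar step on compound 2, the other configuration.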